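The source may report more compounds than this note shows. Statements on the series, on what has been measured and on what is new or still open speak of the compounds shown alone.

Measured so far:
Compound 1, `CS(=O)(=O)c1ccc(Cc2nnc3n2N=C(c2ccc(Cl)cc2Cl)CS3)cc1`, gives 24.2% in a functional assay on HT-29 cells (Homo sapiens) for cytotoxicity, read by MTT assay, with a stated time of 48 h, tested at 25 uM; a higher number here means a stronger effect of the compound at the concentration tested, a lower number a weaker effect.
Compound 2, `Cc1ccc(C2=Nn3c(Cc4ccc(S(C)(=O)=O)cc4)nnc3SC2)cc1`, gives 1.26% in this assay.
Compound 3, `CS(=O)(=O)c1ccc(Cc2nnc3n2N=C(c2cc4ccccc4c(=O)o2)CS3)cc1`, gives 25.6% in this assay.

Compound 2 stands lowest of the three numbers in this assay. Its nearest neighbour is compound 1, which lies higher by a margin beyond the scatter, and compound 3 lies further above it, also beyond the scatter.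

The account now moves from compound 2 to compound 4, `CS(=O)(=O)c1ccc(Cc2nnc3n2N=C(c2cc(Cl)sc2Cl)CS3)cc1`, which has not yet been measured. The change is 2,5-dichlorothiophen-3-yl in place of 4-methylphenyl on a carbon with a double bond to nitrogen.

Within the data shown here, one measured step bears on this change: a number 22.9 percentage points lower from compound 1 to compound 2 (beyond the scatter). There, a 4-methylphenyl replaced a 2,4-dichlorophenyl on the same carbon with a double bond to nitrogen, and the number dropped by a modest amount. The move to compound 4 reverses that direction in kind: the 4-methylphenyl leaves and a ring carrying two chlorines, the 2,5-dichlorothiophen-3-yl, enters at the same place. On that basis a rise is expected for compound 4 in this assay, of a size comparable to the drop seen from compound 1 to compound 2, giving an expected step of a number 18.7 percentage points higher from compound 2 to compound 4 (beyond the scatter). The estimate for compound 4 is therefore 20%, with a range from 5% to 35%.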

Compound 4, a percentage reported as activity, at one concentration (the size of the read-out at that concentration, not a potency): "not active" (no number reported)
For compound 4 the study gives words and no number, and the estimate cannot be compared.
By their numbers in this assay, from the lowest: compound 2; then compounds 1 and 3 (each within the scatter of the next).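

In this assay, among these compounds, compound 4 is reported only in words, as "not active", so no step from compound 2 to compound 4 can be read. Nothing measured here bears on this result. The compounds shown leave open where compound 4 would stand numerically relative to compound 2, which gives 1.26% in this assay.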